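The compounds below may be only part of what the source reports. "The series", "measured", "known", "first", "only" and "open" are said of these compounds alone.

Measured so far:
compound 1 `COc1cccc(C#Cc2ccc3c(n2)CCN(C)C3=O)c1` gives 293 nM
compound 2 `CC(C)N1CCc2nc(C#Cc3ccccc3)ccc2C1=O` gives 706 nM

In a functional assay on HEK293 cells for negative allosteric modulation of metabotropic glutamate receptor 5 (Homo sapiens), read by FLIPR and calcium flux (on this read-out higher numbers stand for weaker inhibition and lower numbers for stronger inhibition), compound 2 gives 706 nM, the highest of the two numbers measured. In this assay compound 1 gives 293 nM, a lower number, and the gap between the two lies beyond the usual scatter of the measurement. The two compounds differ in more than one place, so no single change can be tied to that gap; their two values are all that can be said of the pair.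

Compound 3 `CC(C)N1CCc2nc(C#Cc3ccccn3)ccc2C1=O` has not yet been measured. It differs from compound 2 in a single place: pyridin-2-yl in place of phenyl on a triple-bonded carbon. Among the measured compounds shown here, no step between measured compounds isolates this exchange, so the expectation for compound 3 rests only on where compound 2 stands and on the nature of the change. A small step toward a lower number, if any, is expected, and the step from compound 2 to compound 3 is estimated as a 1.4-fold lower number from compound 2 to compound 3 (0.15 log units; within the scatter), not clearly beyond the scatter. For compound 3 the value in this assay is estimated at 500 nM, with a range from 150 nM to 1500 nM.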

Compound 3, half-maximal inhibitory concentration: 27 nM
Compound 3: the middle estimate sits 19-fold (1.27 log units) above what was measured; the measured number lies below the stated range.
By their numbers in this assay, from the lowest: compound 3; then compound 1; then compound 2.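

In this assay, among the compounds shown here, pyridin-2-yl in place of phenyl on a triple-bonded carbon gives a 26-fold lower number from compound 2 to compound 3 (1.42 log units; beyond the scatter), the first step in the set that can be tied to a single place. It shows that the read-out at this position is highly sensitive to the exchange of one aromatic six-membered ring for another, even though the heavy-atom count, donor count and net charge stay the same and the entering ring adds a ring nitrogen and a hydrogen-bond acceptor. Nothing available explains why the number falls so far, and the data cannot separate the role of the acceptor from any other difference between the two rings.

This single pair leaves open whether the same exchange would have a similar effect on the core of compound 1, which differs from compound 3 in more than one place. From the compounds shown here alone, it also remains open how a pyrimidinyl or thiazolyl ring on the same triple-bonded carbon would read, and whether a ring nitrogen placed elsewhere in the pyridine would keep the step.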